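Series notes: heteroaryl amides, compound 2 toward compound 4

The source may hold more compounds than are shown below. What is called first, only, known or untested is meant among the compounds shown, and "the series" means these compounds.

Measured so far:
compound 1 `Cn1c(C(=O)NCc2ccc(S(=O)(=O)c3ccccc3)cc2)cc2cnccc21` in a functional assay on A2780 cells (Homo sapiens) for inhibition, read by sulforhodamine B assay, with a stated time of 72 h (a higher number here means a weaker inhibitor, a lower number a stronger inhibitor), gives > 10000 nM
compound 2 `O=C(NCc1ccc(S(=O)(=O)c2ccccc2)cc1)c1cc2ncccc2s1` gives > 10000 nM
compound 3 `O=C(NCc1ccc(S(=O)(=O)c2cc(F)cc(F)c2)cc1)c1cc2ccncc2o1` gives 9 nM

Compound 2 returns only a limit of this assay, not a number. It sits at the limit of > 10000 nM in this assay, at which 2 of the 3 values shown sit, where compound 1 also sits. Among the measured compounds shown here, compound 3 is the one compound with a numerical value, and it differs from compound 2 in more than one place, so no single step between measured compounds is available.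

Compound 4 `O=C(NCc1ccc(S(=O)(=O)c2ccccc2)cc1)c1nc2ccncc2s1` is not yet measured. Relative to compound 2 it carries a group of 9 heavy atoms (6 carbon, 2 nitrogen, 1 sulfur; one five-membered aromatic ring with 2 hetero atoms, one six-membered aromatic ring with 1 hetero atom) in place of a group of 9 heavy atoms (7 carbon, 1 nitrogen, 1 sulfur; one five-membered aromatic ring with 1 hetero atom, one six-membered aromatic ring with 1 hetero atom), on a carbonyl carbon.

For the measured compounds named here, with no measured step to lean on and compound 2 at the limit, the expectation for compound 4 is that this assay again reports a limit or a value near it. Compound 4 is estimated at 9000 nM, within 1500 nM to 40000 nM. This estimate means a step of an at least 1.1-fold lower number from compound 2 to compound 4 (0.04 log units; that floor lies within the scatter), expected to lie within the scatter.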

Compound 4, half-maximal inhibitory concentration: > 10000 nM
Compound 4 gave a limit, no number (the forecaster's own chance of this, stated with the estimate: 60%); middle value at least 1.1-fold (0.04 log units) from the limit.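

In this assay compound 2 and compound 4 both return only a limit, so no step between them can be read: the limit of > 10000 nM in this assay, at which 3 of the 4 values shown sit.

Going by these compounds, whether the group entering on the carbonyl carbon changes inhibition at all remains open, as does what separates these compounds from compound 3.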